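Stripping the Ethoxy Group From Compound 3

The source may report more compounds than this note shows. Statements on the series, on what has been measured and on what is new or still open speak of the compounds shown alone.

Compound 1 `CCOc1c(N(C)C)cnn(C)c1=O` gives 49.5% in a functional assay on the whole organism (strain Wistar) for inhibition, with Rattus norvegicus as the target, read by paw edema, with stated times of 30 min and 3 h, at a dose of 100 mg/kg by the oral route (on this read-out lower numbers stand for a weaker effect and higher numbers for a stronger effect at the one dose given), compound 2 `CCOc1c(N2CCCC2)cnn(C)c1=O` gives 23%, and compound 3 `CCOc1ccnn(C)c1=O` gives -12.2%, the lowest of the three numbers. Both steps that remove the amino group were large, a number 61.7 percentage points lower from compound 1 to compound 3 (beyond the scatter) and a number 35.2 percentage points lower from compound 2 to compound 3 (beyond the scatter), while exchanging one amino group for another gave a number 26.5 percentage points lower from compound 1 to compound 2 (beyond the scatter). Compound 4 `Cn1ncccc1=O` differs from compound 3 by hydrogen in place of ethoxy on an aromatic carbon. Going by the values given here, no measured step concerns the ethoxy group, so this change has no direct precedent among the three compounds. Every removal observed so far lowered the number, and compound 4 is therefore expected to give -18%, within -40% to 8%. That estimate means a step of a number 5.8 percentage points lower from compound 3 to compound 4 (within the scatter), which may not clear the scatter.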

Compound 4, a percentage reported as inhibition, in the whole organism at one dose (the size of the read-out at that dose, not a potency): 4.5%
Beside the measured number, compound 4's estimate is 22.5 percentage points below it; the range from low to high includes it.
By their numbers in this assay, from the lowest: compound 3; then compound 4; then compound 2; then compound 1.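

In this assay, going by these compounds alone, this is the first step at the ethoxy position: a number 16.7 percentage points higher from compound 3 to compound 4 (beyond the scatter). Removing ethoxy raised the number, whereas the earlier removals of the amino groups lowered it, a number 61.7 percentage points lower from compound 1 to compound 3 (beyond the scatter) and a number 35.2 percentage points lower from compound 2 to compound 3 (beyond the scatter), so compound 4 goes against any rule that stripping a group lowers the read-out. Nothing at hand explains this difference in direction. Still open, from the compounds shown here alone, is whether hydrogen in place of ethoxy has the same outcome with dimethylamino or pyrrolidin-1-yl present. Going by these compounds, how a methoxy group or a longer alkoxy chain would read on this aromatic carbon is also open.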